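Aryl group change at the benzylic ether carbon

The source may report more compounds than this note shows. Statements on the series, on what has been measured and on what is new or still open speak of the compounds shown alone.

Compound 3 `COc1ccccc1N1CCN(CCC(Oc2ccc(C(=O)Nc3ccccc3OCCCC(=O)O)cc2)c2cccc(C)c2)CC1` gives 360 nM in an assay on isolated protein for inhibition of steroid 5-alpha-reductase (Rattus norvegicus) (on this read-out higher numbers stand for weaker inhibition and lower numbers for stronger inhibition), the second highest of the three numbers; it sits within the scatter of compound 1 `COc1ccccc1N1CCN(CCC(Oc2ccc(NC(=O)c3ccccc3OCCCC(=O)O)cc2)c2ccc(C)cc2)CC1`, which gives 440 nM. Compound 2 `CCc1ccc(C(CCN2CCN(c3ccccc3OC)CC2)Oc2ccc(NC(=O)c3ccccc3OCCCC(=O)O)cc2)cc1` gives 130 nM, and compound 3 lies beyond the scatter above it. Compound 4 `COc1ccc(C(CCN2CCN(c3ccccc3OC)CC2)Oc2ccc(C(=O)Nc3ccccc3OCCCC(=O)O)cc2)cc1` has not been measured; it differs from compound 3 in that (4-methoxyphenyl in place of 3-methylphenyl on a saturated chain carbon bound to an oxygen on an aromatic ring and a saturated chain carbon). Going by the values given here, the only measured step on this aryl group is a 3.4-fold lower number from compound 1 to compound 2 (0.53 log units; beyond the scatter), a change that also enlarges the substituent on the same ring; it shows that this position tolerates, and may reward, a larger group. Among the compounds with values here, the present change moves the substituent and adds an oxygen, so it has no direct precedent among the three compounds and the step from compound 1 to compound 3 is confounded by a second difference. A modest lowering or no change beyond the scatter is therefore expected for compound 4, with a 1.4-fold lower number from compound 3 to compound 4 (0.16 log units; within the scatter) as the expected step. Compound 4 is estimated at 250 nM, with a range of 90 nM to 700 nM.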

Compound 4, half-maximal inhibitory concentration: 170 nM
Compound 4: middle estimate off by 1.5-fold (0.17 log units), on the high side; the range from low to high includes it.
By their numbers in this assay, from the lowest: compounds 2 and 4 (each within the scatter of the next); then compounds 3 and 1 (each within the scatter of the next).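

In this assay, 4-methoxyphenyl in place of 3-methylphenyl on a saturated chain carbon bound to an oxygen on an aromatic ring and a saturated chain carbon gives a 2.1-fold lower number from compound 3 to compound 4 (0.33 log units; beyond the scatter). Going by these compounds alone, this is the first step on this aryl group read with the amide turned as in compound 3, and it runs in the same direction as a 3.4-fold lower number from compound 1 to compound 2 (0.53 log units; beyond the scatter), which was read with the amide turned the other way and involves a different aryl change. No measurement at hand accounts for either step.

The compounds shown leave open whether the methoxy group or its changed place on the ring carries the step, a question that 3-methoxyphenyl and 4-methylphenyl on the same carbon would separate. Also open, from the compounds shown here alone, is whether a fluorine or a hydroxyl on this ring would lower the number.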